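The source may hold more compounds than are shown below. What is called first, only, known or untested is meant among the compounds shown, and "the series" means these compounds.

Working notes on the series. Three compounds share a core; compound 1 `CC(C(=O)NCc1ccc(C(F)(F)F)cc1N1CCC(C)(C)CC1)c1ccc(NS(C)(=O)=O)c(F)c1`, compound 2 `CC(C(=O)NCc1ccc(C(F)(F)F)cc1N1CCC(Cc2ccccc2)CC1)c1ccc(NS(C)(=O)=O)c(F)c1` and compound 3 `CCCCCCOc1cc(C(C)(F)F)ccc1CNC(=O)C(C)c1ccc(NS(C)(=O)=O)c(F)c1` have all been run in an assay on CHO cells for antagonist activity at transient receptor potential cation channel subfamily V member 1 (Homo sapiens), read by FLIPR; on this read-out lower numbers stand for stronger inhibition and higher numbers for weaker inhibition. Compound 1 gives 1.3 nM, compound 2 gives 1.4 nM and compound 3 gives 0.8 nM. Compound 1 stands second highest of the three numbers, nearest to compound 2, furthest from compound 3, and both gaps lie within the scatter, so the three values show no separation.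

Compound 4 `CC(C)CCSc1cc(C(F)(F)F)ccc1CNC(=O)C(C)c1ccc(NS(C)(=O)=O)c(F)c1` is not yet measured in this assay. It departs from compound 1 in one place: isopentylsulfanyl in place of 4,4-dimethylpiperidin-1-yl on an aromatic carbon. The 4,4-dimethylpiperidin-1-yl group leaves and a chain without a ring enters. Compound 3 carries an open chain rather than a six-membered non-aromatic ring and gives 0.8 nM, a number that sits within the scatter of compound 1, so the move from a ring to a chain has not so far been tied to any step beyond the scatter.

For compound 4 the step of a 1.1-fold lower number from compound 1 to compound 4 (0.03 log units; within the scatter) is therefore expected to stay within the scatter, in no particular direction. Compound 4 is estimated at 1.2 nM, with a range from 0.5 nM to 3 nM.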

Compound 4, inhibition constant: 1.4 nM
Estimate against measurement, compound 4: 1.2-fold (0.07 log units) below; measured number inside the range.
By their numbers in this assay, from the lowest: compounds 3, 1, 2 and 4 (each within the scatter of the next).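

Read in this assay, isopentylsulfanyl in place of 4,4-dimethylpiperidin-1-yl gives a 1.1-fold higher number from compound 1 to compound 4 (0.03 log units; within the scatter), the only direct one-place reading so far of a ring-to-chain exchange on this aromatic carbon, which is ortho to a large group and meta to a trifluoromethyl group. For this pair, the six-membered non-aromatic ring is not needed to keep the number in the range of compound 1: an open chain joined through sulfur, with no ring and no nitrogen, stays within the scatter of compound 1. No measurement at hand accounts for why the two groups read alike.

Open, on these data alone, is whether sulfur itself plays any part in this result, a question that an isopentyloxy or a plain hexyl group at the same carbon would separate from the effect of the chain. Also open, as far as these compounds go, is how far this tolerance extends, for instance to a much shorter group such as methoxy, or to a chain ending in a carboxylic acid or a primary amine, where a step beyond the scatter might first appear.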